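This account rests on a few compounds, and the source may have more. Where it says the series, first, only, none or still open, it means among the compounds named here.

In a functional assay on KB cells (Homo sapiens) for antiproliferative activity, read by sulforhodamine B assay, with a stated time of 48 h (on this read-out higher numbers stand for weaker inhibition of growth and lower numbers for stronger inhibition of growth), compound 1 (`COc1ccc(S(=O)(=O)Nc2ccccc2CCc2ccc(C(=O)Nc3ccccc3N)cc2)cc1`) gives 23 nM, while compound 2 (`COc1ccc(S(=O)(=O)Nc2ccccc2CCc2ccc(C(=O)Nc3cccc(N)c3)cc2)cc1`) gives 697 nM, the higher of the two numbers. Compound 3 (`COc1ccc(S(=O)(=O)Nc2ccccc2CCc2ccccc2)cc1`) is still unmeasured. It differs from compound 2 by one change (hydrogen in place of (3-aminophenyl)carbamoyl on an aromatic carbon), hydrogen in place of (3-aminophenyl)carbamoyl on an aromatic carbon. Going by the values given here, the one measured step that bears on this (a 30-fold higher number from compound 1 to compound 2 (1.48 log units; beyond the scatter)) is large and arose inside that same group, yet no measured step removes the group whole. A step towards a higher number is therefore expected in this assay, with an estimated size of a 4.3-fold higher number from compound 2 to compound 3 (0.63 log units; beyond the scatter). For compound 3 the expected value is 3000 nM, within an estimated range from 400 nM to 20000 nM.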

Compound 3, concentration for 50% growth inhibition: 4410 nM
Estimate against measurement, compound 3: 1.5-fold (0.17 log units) below; measured number inside the range.
By their numbers in this assay, from the lowest: compound 1; then compound 2; then compound 3.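

Removing the whole (3-aminophenyl)carbamoyl group from the aromatic carbon still weakens growth inhibition in this assay, with a 6.3-fold higher number from compound 2 to compound 3 (0.80 log units; beyond the scatter). Even the weaker of the two amides therefore keeps some of what the group contributes, while removing the (2-aminophenyl)carbamoyl group costs far more, with a 190-fold higher number from compound 1 to compound 3 (2.28 log units; beyond the scatter). No measurement here explains why this group matters. Still open, from the compounds shown here alone, is how much of the group is needed: a carboxylic acid or a plain unsubstituted amide at this place could separate the contribution of the carbonyl from that of the aminophenyl ring.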